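A few compounds are considered here, and "the series" means these few. Any claim that something is new, unique, unknown or untested is made for them only; others in the source may bear on it.

Of the compounds shown here, two have so far been measured in an assay for inhibition of Fatty-acid amide hydrolase 1 (Rattus norvegicus); a lower number here means a stronger inhibitor, a higher number a weaker inhibitor. Compound 1 `COC(=O)c1ccc(-c2cnc(C(=O)CCc3ccc(-c4ccccc4)cc3)o2)nc1` gives 2.2 nM. Compound 2 `O=C(CCc1ccc(COc2ccccc2)cc1)c1ncco1` gives 25 nM, the highest of the two numbers, and the gap to compound 1 lies beyond the usual scatter. The two compounds differ in more than one place, so their values alone do not show which part of the structure accounts for that gap.

Compound 3 `O=C(CCc1ccc(COc2ccccc2)cc1)c1ncc(-c2cccc(-c3nnn[nH]3)n2)o1` has not yet been measured. Relative to compound 2 it carries 6-(1H-tetrazol-5-yl)pyridin-2-yl in place of hydrogen on an aromatic carbon. Compound 1 also bears a large group at that same ring position, and its value of 2.2 nM is the only pointer available, so the expected step of an 8.3-fold lower number from compound 2 to compound 3 (0.92 log units; beyond the scatter) is toward stronger inhibition, of a size that is uncertain. Compound 3 is therefore estimated at 3 nM, with a likely range from 0.8 nM to 12 nM.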

Compound 3, inhibition constant: 21 nM
The estimate for compound 3 lay 7.0-fold (0.85 log units) below the measured number; measured number outside the range, above it.
By their numbers in this assay, from the lowest: compound 1; then compounds 3 and 2 (each within the scatter of the next).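

In this assay, putting 6-(1H-tetrazol-5-yl)pyridin-2-yl in place of hydrogen on the aromatic carbon next to the ring oxygen gives a 1.2-fold lower number from compound 2 to compound 3 (0.08 log units; within the scatter), so compound 2 and compound 3 cannot be told apart. This position therefore accepts a group of 11 heavy atoms with no measurable penalty, but the size of a group here does not by itself bring a stronger number. Nothing available explains why this group leaves the value within the scatter.

On these data alone, it remains open whether a plain pyridin-2-yl, or a pyridine carrying a carboxylic acid or a methyl ester in place of the tetrazole, would behave the same way on this core. As far as these compounds go, compound 1 differs from compound 3 in more than one place, so the part of the structure behind its lower number is still unknown.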